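A few compounds are considered here, and "the series" means these few. Any claim that something is new, unique, unknown or untested is made for them only; others in the source may bear on it.

Working notes on the series. Of the compounds shown here, two have been measured in an assay on isolated protein for inhibition of metabotropic glutamate receptor 5 (Homo sapiens), tested at 10 uM; on this read-out higher numbers stand for more inhibition at the one concentration tested (going by the name of the read-out) and lower numbers for less inhibition. Compound 1, `Cc1ccc(C(=O)N2CCCN2C(=O)c2ccc(N3C(=O)C4CC=CCC4C3=O)cc2)cc1C`, gives < 35% in this assay, and that figure is a limit of the assay rather than a number. Going by the values given here, compound 2, `Cc1ccc(C(=O)COC(=O)c2ccc(N3C(=O)COCC3=O)cc2)cc1C`, gives 41% in this assay; this is the only numerical value obtained so far, so compound 2 stands alone as a reference point. Among the compounds with values here, the evidence on the measured compounds is thin: the limit of < 35% in this assay, at which 1 of the 2 values shown sits, and no step between two measured compounds can be drawn.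

The next compound to be tested is compound 3, `Cc1ccc(C(=O)COC(=O)c2ccc(N3CCCC3=O)cc2)cc1C`, which differs from compound 2 in one place: 2-oxopyrrolidin-1-yl in place of 3,5-dioxomorpholin-4-yl on an aromatic carbon. Within the data shown here, with no measured step on which to rest, the size of the change expected in this assay is small, at most a slight shift downward from compound 2, not clearly beyond the scatter. Compound 3 is therefore estimated at 37% in this assay, within a range of 22% to 52%, and the expected step of a number 4 percentage points lower from compound 2 to compound 3 (within the scatter) is accordingly modest.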

Compound 3, a percentage reported as inhibition, at one concentration (the size of the read-out at that concentration, not a potency): 38%
Beside the measured number, compound 3's estimate is 1 percentage points below it; low and high end bracket the measured number.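

The series now has its first step, at an aromatic carbon para to a large group: in this assay, with 2-oxopyrrolidin-1-yl in place of 3,5-dioxomorpholin-4-yl, the step is a number 3 percentage points lower from compound 2 to compound 3 (within the scatter). The entering five-membered ring has fewer heavy atoms, one hetero atom, one double bond outside aromatic rings and fewer hydrogen-bond acceptors than the six-membered ring it replaces, yet this exchange does not separate compound 2 and compound 3 beyond the scatter. Nothing shown gives a cause for this step.

Going by these compounds, whether any group at this place moves the read-out beyond the scatter stays open, for example an amine, a carboxylic acid or a longer chain in place of 2-oxopyrrolidin-1-yl. Going by these compounds alone, compound 1 gives < 35%, which is a limit and not a number, and it differs from compound 2 and compound 3 in more than one place, so no step to it can be read.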